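Amide Nitrogen Substituent Change in a Thiophene Methyl Ether Series

The compounds below may be only part of what the source reports. "The series", "measured", "known", "first", "only" and "open" are said of these compounds alone.

Compound 1 `Cc1ccc(OCC(=O)N(CCO)Cc2cccs2)cc1`: 900 nM
Compound 2 `CCN(Cc1cccs1)C(=O)COc1cccc(C)c1`: 97 nM
Compound 3 `Cc1ccc(OC2CCN(Cc3cccs3)C2=O)cc1`: "not active" (no number reported)

In an assay on HEK293 cells for agonist activity at transient receptor potential cation channel subfamily M member 8 (Homo sapiens), read by fluorescence and calcium flux, with a stated time of 15 min (on this read-out lower numbers stand for an effect already at smaller amounts and higher numbers for an effect only at larger amounts of compound), compound 1 gives 900 nM, the highest of the two numbers reported; compound 2 gives 97 nM, a gap beyond the scatter, and compound 3 gave no number at all. Compound 4 `Cc1ccc(OCC(=O)N(Cc2cccs2)c2cnccn2)cc1` differs from compound 1 at one place: pyrazin-2-yl in place of 2-hydroxyethyl on an amide-type nitrogen. For the measured compounds named here, no measured pair shows this change, so the direction is uncertain. Since compound 2, which also carries no hydroxyl group, gives 97 nM, a modest step to a lower number from compound 1 to compound 4 is expected, a 1.8-fold lower number from compound 1 to compound 4 (0.26 log units; within the scatter), though a step in either direction remains possible. Compound 4 is estimated at 500 nM, within 120 nM to 2500 nM.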

Compound 4, half-maximal effective concentration: 1240 nM
The estimate for compound 4 lay 2.5-fold (0.39 log units) below the measured number, within the range that was stated.
By their numbers in this assay, from the lowest: compound 2; then compounds 1 and 4 (each within the scatter of the next).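

In this assay, placing pyrazin-2-yl instead of 2-hydroxyethyl on the amide-type nitrogen gives a 1.4-fold higher number from compound 1 to compound 4 (0.14 log units; within the scatter) and so leaves the number within the scatter. This position therefore takes a six-membered aromatic ring in place of an open chain, and the number stays within the scatter even though the hydrogen-bond donor of compound 1 is gone. Nothing measured here accounts for this result.

The compounds shown leave open how a phenyl ring, a pyridine ring or a carboxylic acid would read on this nitrogen. They also leave open whether a longer chain ending in an amine would differ from 2-hydroxyethyl.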